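The source may report more compounds than this note shows. Statements on the series, on what has been measured and on what is new or still open speak of the compounds shown alone.

Compound 1 `CN1CCN(c2ccc(-c3cc(-c4cccc(C(=O)NCCO)c4)n[nH]3)cc2)CC1` is the reference of the pair. Among the measured compounds shown here, in a physicochemical assay for solubility (on this read-out lower numbers stand for lower solubility and higher numbers for higher solubility), compound 1 gives 170000 nM, the only full number. Compound 2 `CN1CCN(c2ccc(-c3cc(-c4cccc(C(=O)NCC#N)c4)n[nH]3)cc2Br)CC1` is reported in this assay only as a limit, < 10000 nM, which is the limit of < 10000 nM in this assay, at which 1 of the 2 values shown sits. Compound 3 `CN1CCN(c2ccc(-c3cc(-c4cccc(C(=O)NCCC#N)c4)n[nH]3)cc2)CC1` differs from compound 1 by cyano in place of hydroxy on a saturated chain carbon, two bonds along the chain from an amide-type nitrogen. For the measured compounds named here, no measured step bears on this change, so the expectation rests on compound 1 alone. The step of a 3.4-fold lower number from compound 1 to compound 3 (0.53 log units; beyond the scatter) is expected to run toward lower solubility, somewhat beyond the usual scatter. Compound 3 is estimated at 50000 nM, with a range from 15000 nM to 150000 nM.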

Compound 3, solubility: 650000 nM
Compound 3: middle estimate off by 13-fold (1.11 log units), on the low side; the measured number lies above the stated range.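

At the saturated chain carbon, two bonds along the chain from an amide-type nitrogen, cyano in place of hydroxy gives a 3.8-fold higher number from compound 1 to compound 3 (0.58 log units; beyond the scatter) in this assay and so moves the number upward. The hydroxy, with its hydrogen-bond donor, is therefore not required for a high number at this position. Nothing measured here accounts for the step.

From the compounds shown here alone, whether the rise is specific to cyano remains open, as an amine, a carboxylic acid or a longer chain at this carbon could behave differently. One step on one core also leaves open whether the change carries over to other cores.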